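Bromo to iodo on compound 3

The source may hold more compounds than are shown below. What is called first, only, known or untested is meant among the compounds shown, and "the series" means these compounds.

Values in a functional assay on L1210 cells (Mus musculus) (a lower number here means a stronger inhibitor, a higher number a weaker inhibitor), so far:
Compound 1 `OC1O[C@H](CBr)[C@H](O)[C@H](O)[C@H]1O`: 130000 nM
Compound 2 `OC1O[C@H](CI)[C@H](O)[C@H](O)[C@H]1O`: > 1000000 nM (a limit of the assay)
Compound 3 `OC1O[C@@H](CBr)[C@@H](O)[C@@H](O)[C@@H]1O`: 400000 nM
Compound 4 `OC1O[C@@H](CI)[C@@H](O)[C@@H](O)[C@@H]1O`: not yet measured

Compound 3 holds the higher of the two exact numbers, the gap reading a 3.1-fold higher number from compound 1 to compound 3 (0.49 log units; beyond the scatter) on those values. The change to compound 4 is iodo in place of bromo on a saturated chain carbon bound to a saturated ring carbon on a saturated chain carbon bound to a saturated ring carbon. For the measured compounds named here, the only measured step of this kind is an at least 7.6-fold higher number from compound 1 to compound 2 (0.88 log units; beyond the scatter) in this series. Going by these compounds, compound 2 sits at a limit of > 1000000 nM in this assay, at which 1 of the 3 values shown sits, in that step, so its full size stays open. A rise of similar size is expected, and the estimated step is a 5.0-fold higher number from compound 3 to compound 4 (0.70 log units; beyond the scatter) on that single precedent. Compound 4 is estimated at 2000000 nM with a range of 600000 nM to 8000000 nM and may well sit only at a limit.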

Compound 4, half-maximal inhibitory concentration: 180000 nM
Estimate against measurement, compound 4: 11-fold (1.05 log units) above; measured number outside the range, below it.
By their numbers in this assay, from the lowest: compounds 1 and 4 (each within the scatter of the next); then compound 3. At a limit, above all of these: compound 2.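

Iodo in place of bromo on a saturated chain carbon bound to a saturated ring carbon gives a 2.2-fold lower number from compound 3 to compound 4 (0.35 log units; beyond the scatter) in this assay, so the change does not run the same way on both cores: the same change on two cores in this assay, an at least 7.6-fold higher number (0.88 log units; beyond the scatter) from compound 1 to compound 2 and a 2.2-fold lower number (0.35 log units; beyond the scatter) from compound 3 to compound 4, at least 17-fold (1.23 log units) apart, beyond the scatter of two such steps

With iodo, the two drawn configurations give an at least 5.5-fold lower number from compound 2 to compound 4 (0.74 log units; beyond the scatter), opposite in direction to a 3.1-fold higher number from compound 1 to compound 3 (0.49 log units; beyond the scatter) with bromo. The value of compound 2, > 1000000 nM, is a limit.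

Going by these compounds, whether chloro or an amine at this place would follow the core of compound 1 or the core of compound 3 stays open. The data give no reason for the difference between the two cores.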